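This account rests on a few compounds, and the source may have more. Where it says the series, first, only, none or still open, it means among the compounds named here.

Of the compounds shown here, three built on one shared core have been tested in an ADME assay on HEK293-A cells (Homo sapiens) for cytotoxicity, read by MTT assay, with a stated time of 48 h; on this read-out higher numbers stand for weaker inhibition and lower numbers for stronger inhibition. Compound 1 `O=C1CSC(=O)N1C[C@H]1CN(c2ccc(-n3cc(-c4ccccn4)cn3)c(F)c2)C(=O)O1` carries a 2,4-dioxo-1,3-thiazolidin-3-yl group on a saturated chain carbon bound to a saturated ring carbon, and in this assay compound 1 gives 283 ug/mL. Compound 2 `O=C1O[C@@H](Cn2ccnc2)CN1c1ccc(-n2cc(-c3ccccn3)cn2)c(F)c1` has 1H-imidazol-1-yl in that place, and in this assay compound 2 reaches only the assay limit, > 400 ug/mL. Compound 3 `O=CNC[C@H]1CN(c2ccc(-n3cc(-c4ccccn4)cn3)c(F)c2)C(=O)O1` carries formylamino there, and in this assay compound 3 also reports only the limit, > 400 ug/mL. Compound 3 thus sits at the limit of > 400 ug/mL in this assay, at which 2 of the 3 values shown sit, so its true number is not known. The steps leading to it are floors or unreadable: an at least 1.4-fold higher number from compound 1 to compound 3 (0.15 log units; that floor lies within the scatter), an at least 1.4-fold higher number from compound 1 to compound 2 (0.15 log units; that floor lies within the scatter), and a step that the two limits leave unreadable from compound 2 to compound 3.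

Compound 4 `CCNC(=O)NC[C@H]1CN(c2ccc(-n3cc(-c4ccccn4)cn3)c(F)c2)C(=O)O1` differs from compound 3 by ethylamino in place of hydrogen on a carbonyl carbon. Going by the values given here, no measured step follows such a change, and the steps known all end at the limit, so compound 4 is expected to stay there too. The expected step is a step that the limit leaves unreadable from compound 3 to compound 4, nothing beyond the scatter. Compound 4 is therefore estimated at 450 ug/mL, between 250 ug/mL and 800 ug/mL.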

Compound 4, half-maximal inhibitory concentration: 29 ug/mL
Beside the measured number, compound 4's estimate is 16-fold (1.19 log units) above it; measured number outside the range, below it.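

Ethylamino in place of hydrogen on a carbonyl carbon gives an at least 13-fold lower number from compound 3 to compound 4 (1.13 log units; beyond the scatter) in this assay, so this position can move the number well beyond the scatter. Changing the group here also gives an at least 13-fold lower number from compound 2 to compound 4 (1.13 log units; beyond the scatter) and a 9.8-fold lower number from compound 1 to compound 4 (0.99 log units; beyond the scatter), which makes compound 4 the most strongly inhibiting of the four, with steps beyond the scatter to all three others. Two of these steps are only floors, because compound 2 and compound 3 reach no true number: the limit of > 400 ug/mL in this assay, at which 2 of the 4 values shown sit.

From the compounds shown here alone, what remains open is whether a shorter methylamino group, a longer propylamino chain or a plain amino group in the place of ethylamino would give a similar number. Going by these compounds, the true distance from compound 3 to compound 4 also remains unknown.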